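Removing the Methyl from a Pyrazole Nitrogen: Compound 4

A few compounds are considered here, and "the series" means these few. Any claim that something is new, unique, unknown or untested is made for them only; others in the source may bear on it.

Compound 1, `Cc1ccc(-c2ccccc2NCC2=NCCN2)n1C`: 78%
Compound 2, `Cn1cc(-c2ccccc2NCC2=NCCN2)cn1`: 39%
Compound 3, `CCCn1nccc1-c1ccccc1NCC1=NCCN1`: 59%

In a functional assay with Alpha-1A adrenergic receptor (Homo sapiens) as the target, read by calcium flux (a lower number here means a smaller maximal response, a higher number a larger maximal response), compound 1 gives 78%, compound 2 gives 39% and compound 3 gives 59%. Compound 2 thus stands lowest of the three numbers; its gap to compound 3 and its wider gap to compound 1 both lie beyond the scatter. Compound 4, `c1ccc(-c2cn[nH]c2)c(NCC2=NCCN2)c1`, has not yet been measured in this assay. Compared with compound 2 it carries hydrogen in place of methyl on an aromatic nitrogen. Among the measured compounds shown here, no pair of measured compounds shows this change on its own, and the three measured compounds differ from one another in more than one place, so the direction of the step cannot be read off from them. A step of modest size, in either direction or none beyond the scatter, is expected. Compound 4 is estimated at 45%, with a range from 25% to 70%. The expected step is a number 6 percentage points higher from compound 2 to compound 4 (within the scatter).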

Compound 4, largest response reached (reported as maximal response), in percent of the reference or control that the assay uses: 112%
Beside the measured number, compound 4's estimate is 67 percentage points below it, outside the stated range (above it).
By their numbers in this assay, from the lowest: compound 2; then compound 3; then compound 1; then compound 4.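

In this assay, the change from 1-methyl-1H-pyrazol-4-yl to 1H-pyrazol-4-yl gives a number 73 percentage points higher from compound 2 to compound 4 (beyond the scatter) and thereby shows what the earlier compounds could not: a single methyl on this aromatic nitrogen can by itself account for a large shift in maximal response. With only one carbon leaving and the rest of the structure unchanged, this position clearly has a strong influence on the read-out, at least in this pair. No measurement shown here accounts for why the step is so large.

The compounds shown leave open whether an ethyl group or a longer chain such as butyl on the same nitrogen would give a number closer to that of compound 2 or compound 4. They also leave open whether a hydroxyethyl or acetyl group there would fit the same picture.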